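The source may report more compounds than this note shows. Statements on the series, on what has been measured and on what is new or still open speak of the compounds shown alone.

Measured so far:
Compound 1 `CCOc1ccc(C(=O)/C=C/c2ccc(C(=O)Nc3cccc(-c4cc(C(=O)OC)no4)c3)cc2)cc1` — in an ADME assay on Vero cells (Chlorocebus sabaeus) for cytotoxicity, read by MTT assay, with a stated time of 72 h (on this read-out higher numbers stand for lower toxicity in this test and lower numbers for higher toxicity in this test), compound 1 gives > 40 ug/mL, which is a limit of the test rather than a number.
Compound 2 `COC(=O)c1cc(-c2ccc(NC(=O)c3ccc(/C=C/C(=O)c4ccc(Cl)cc4)cc3)cc2)on1` — in this assay compound 2 gives > 80 ug/mL, again only a limit.

Compound 1 stands at the limit of > 40 ug/mL in this assay, at which 1 of the 2 values shown sits. The other measured value, for compound 2, is also a limit, at the limit of > 80 ug/mL in this assay, at which 1 of the 2 values shown sits. Going by the values given here, neither is a full number, so no step between the two compounds can be measured, and only what each limit shows is known.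

Compound 3 `COC(=O)c1cc(-c2cccc(NC(=O)c3ccc(/C=C/C(=O)c4cccc([N+](=O)[O-])c4)cc3)c2)on1` is not yet measured. It differs from compound 1 by 3-nitrophenyl in place of 4-ethoxyphenyl on a carbonyl carbon. Among the compounds with values here, no measured step covers a change of this kind, so the size of its effect cannot be read from the data. For compound 3 in this assay the expected step is a step that the limit leaves unreadable from compound 1 to compound 3, not beyond the usual scatter. Compound 3 is therefore estimated at 60 ug/mL, within 30 ug/mL to 120 ug/mL, with a fair chance that only a limit is reported again.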

Compound 3, half-maximal cytotoxic concentration: > 40 ug/mL
Compound 3: no number, only a limit; the forecaster's own chance of this, stated with the estimate: 70%; the middle value lies beyond the limit too.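

Compound 1 and compound 3 both give only a limit rather than a number, so no step between them can be read: the limit of > 40 ug/mL in this assay, at which 2 of the 3 values shown sit.

The compounds shown leave open how far each true value lies past its limit, and so whether 3-nitrophenyl in place of 4-ethoxyphenyl on a carbonyl carbon changes the read-out at all.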